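The source may report more compounds than this note shows. Statements on the series, on what has been measured and on what is new or still open speak of the compounds shown alone.

Measured compounds:
- compound 1, `S=c1oc(-c2ccc3c(c2)OCCO3)nn1CNc1ccccc1Cl`: 7230 nM
- compound 2, `S=c1oc(-c2ccc3c(c2)OCCO3)nn1CNc1ccc(Cl)cc1Cl`: 8710 nM
- compound 3, `S=c1oc(-c2ccc3c(c2)OCCO3)nn1CNc1ccc(Cl)c(Cl)c1`: 6840 nM

All three numbers come from a functional assay, with a stated time of 6 min; on this read-out lower numbers stand for stronger inhibition and higher numbers for weaker inhibition. Compound 1 sits in the middle of the three: the step of a 1.2-fold higher number from compound 1 to compound 2 (0.08 log units; within the scatter) and the step of a 1.1-fold lower number from compound 1 to compound 3 (0.02 log units; within the scatter) both lie within the scatter, as does the step of a 1.3-fold lower number from compound 2 to compound 3 (0.10 log units; within the scatter). Changing the chlorine pattern on the aniline ring therefore leaves this assay essentially unmoved across compounds 1, 2 and 3.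

Compound 4, `O=[N+]([O-])c1ccc(NCn2nc(-c3ccc4c(c3)OCCO4)oc2=S)cc1`, differs from compound 1 in one place: 4-nitrophenyl in place of 2-chlorophenyl on an amine nitrogen

For the measured compounds named here, no measured step exchanges a chlorine for a nitro group, so only indirect evidence bears on this change. Every measured step on the same aniline ring stayed within the scatter, which gives no reason to expect the step from compound 1 to compound 4 to be large in either direction. The expected step is therefore a 1.0-fold higher number from compound 1 to compound 4 (0.02 log units; within the scatter), with a wide range to reflect the lack of a direct precedent. For compound 4 the estimate in this assay is 7500 nM, expected to fall between 3000 nM and 18000 nM.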

Compound 4, half-maximal inhibitory concentration: 9950 nM
Compound 4: the middle estimate sits 1.3-fold (0.12 log units) below what was measured; the range from low to high includes it.
By their numbers in this assay, from the lowest: compounds 3, 1, 2 and 4 (each within the scatter of the next).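

In this assay, 4-nitrophenyl on the amine nitrogen stays within the scatter of all three chlorinated rings, with a 1.4-fold higher number from compound 1 to compound 4 (0.14 log units; within the scatter) and a 1.5-fold higher number from compound 3 to compound 4 (0.16 log units; within the scatter) and also a 1.1-fold higher number from compound 2 to compound 4 (0.06 log units; within the scatter) as the steps. The earlier compounds shown here varied only the number and placement of chlorine on this ring, whereas compound 4 carries no chlorine at all and brings a nitro group with 2 hydrogen-bond acceptors, so the flat picture now extends beyond chlorine to a second kind of substituted phenyl. No measurement offered here accounts for this result.

Going by these compounds, it remains open whether a group of another kind on this ring, such as a carboxylic acid or an amine, would move the number beyond the scatter. Also open, on these data alone, is whether replacing the phenyl ring with a cyclohexyl ring or a longer chain, or altering the shared core, would do so.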